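The source may report more compounds than this note shows. Statements on the series, on what has been measured and on what is new or still open speak of the compounds shown alone.

Compound 1 `O=C(O)c1ccccc1-c1ccc(CCc2ncc(C3CCCCC3)[nH]2)cc1` is the starting point. In an in vitro functional assay on cells for agonist activity at Bombesin receptor subtype-3 (Homo sapiens), read by luminescence and calcium flux (a higher number here means that more compound is needed for the effect, a lower number that less compound is needed), compound 1 gives 375 nM, the lowest of the three numbers measured, so it needs the least compound of the three. Its two companions keep the shared core and differ only in the group on an aromatic carbon: compound 2 `O=C(O)c1ccccc1-c1ccc(CCc2ncc(CCc3ccccc3)[nH]2)cc1` gives 1320 nM, and compound 3 `O=C(O)c1ccccc1-c1ccc(CCc2ncc(CC3CC3)[nH]2)cc1` gives 1000 nM. Both replacements of cyclohexyl moved the number up by a modest amount: a 3.5-fold higher number from compound 1 to compound 2 (0.55 log units; beyond the scatter) and a 2.7-fold higher number from compound 1 to compound 3 (0.43 log units; beyond the scatter). Between those two, a 1.3-fold lower number from compound 2 to compound 3 (0.12 log units; within the scatter), so the two replacements cannot be told apart from each other.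

Compound 4 `CCC(C)(CC)Cc1cnc(CCc2ccc(-c3ccccc3C(=O)O)cc2)[nH]1` makes a change of the same kind: 2-ethyl-2-methylbutyl in place of cyclohexyl on an aromatic carbon. The two measured steps from compound 1 that bear on it each gave a modestly higher number, and neither a ring nor a chain of similar size has yet matched cyclohexyl. A modest rise in this assay is therefore expected for compound 4 as well, a 2.0-fold higher number from compound 1 to compound 4 (0.30 log units; within the scatter). Compound 4 is estimated at 750 nM, with a likely range from 300 nM to 1900 nM.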

Compound 4, half-maximal effective concentration: 76 nM
Beside the measured number, compound 4's estimate is 9.9-fold (0.99 log units) above it; measured number outside the range, below it.
By their numbers in this assay, from the lowest: compound 4; then compound 1; then compounds 3 and 2 (each within the scatter of the next).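

At this position, on an aromatic carbon of a five-membered aromatic ring with 2 nitrogen, an open branched chain outdoes the ring of cyclohexyl in this assay: there is a 4.9-fold lower number from compound 1 to compound 4 (0.69 log units; beyond the scatter) and the earlier replacements had only raised the number. The gaps to the other two groups are wider still, with a 13-fold lower number from compound 3 to compound 4 (1.12 log units; beyond the scatter) and a 17-fold lower number from compound 2 to compound 4 (1.24 log units; beyond the scatter), so the choice of group here can matter more than the first three compounds suggested. No measurement offered here accounts for this gain.

A straight hexyl chain or a smaller branched group such as 2,2-dimethylpropyl would help show whether the branching matters or the chain length does. An amine placed in the chain would test whether this position needs a group of carbon only.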